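Ester variation and liver microsome stability on the shared core

This account rests on a few compounds, and the source may have more. Where it says the series, first, only, none or still open, it means among the compounds named here.

Compound 2 `CCCCc1nc(C(C)C)c(CC(=O)OC(CC)CC)c(=O)n1Cc1ccc(-c2ccccc2-c2noc(=O)[nH]2)cc1` stands highest of the two numbers in an ADME assay on microsomes from liver (Homo sapiens) for metabolic stability, with a stated time of 30 min (on this read-out higher numbers stand for a more stable compound and lower numbers for a less stable compound), with 7.7%, though only within the scatter of compound 1 `CCCCOC(=O)Cc1c(C(C)C)nc(CCCC)n(Cc2ccc(-c3ccccc3-c3noc(=O)[nH]3)cc2)c1=O`, which gives 7.1%. Compound 3 `CCCCc1nc(C(C)C)c(C(C)C(=O)OCC)c(=O)n1Cc1ccc(-c2ccccc2-c2noc(=O)[nH]2)cc1` carries 1-(ethoxycarbonyl)ethyl in place of (((pentan-3-yl)oxy)carbonyl)methyl on an aromatic carbon. For the measured compounds named here, the one measured step that bears on this, a number 0.6 percentage points higher from compound 1 to compound 2 (within the scatter), also exchanged the alkyl on the ester oxygen and moved nothing beyond the scatter, so for compound 3 no step beyond the scatter is expected in this assay, with the direction open. Compound 3 is therefore estimated at 10%, in the range 3% to 25%, an expected step of a number 2.3 percentage points higher from compound 2 to compound 3 (within the scatter).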

Compound 3, percent of the compound remaining: 11%
Estimate against measurement, compound 3: 1 percentage points below; the range from low to high includes it.
By their numbers in this assay, from the lowest: compounds 1, 2 and 3 (each within the scatter of the next).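

At the aromatic carbon ortho to the isopropyl group, the change now reaches the branched carbon of the side chain as well as the alkyl on the ester oxygen, and the steps stay within the scatter in this assay (a number 3.3 percentage points higher from compound 2 to compound 3 (within the scatter); a number 3.9 percentage points higher from compound 1 to compound 3 (within the scatter)). This single change cannot separate the branched carbon from the ethyl ester. No measured evidence on the cause accompanies these steps. Open, going by these compounds, is whether a carboxylic acid or an amide in place of the ester would give a step beyond the scatter.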